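A few compounds are considered here, and "the series" means these few. Any claim that something is new, unique, unknown or untested is made for them only; others in the source may bear on it.

Measured in a toxicity assay on MT4 cells (Homo sapiens) for cytotoxicity, read by MTT assay, with a stated time of 5 days; on this read-out lower numbers stand for higher toxicity in this test and higher numbers for lower toxicity in this test:
- compound 1 `Cc1cnc(Nc2ccc(C#N)cc2)nc1Nc1c(F)cc(-c2ccsc2)cc1F`: 261000 nM
- compound 2 `Cc1cnc(Nc2ccc(C#N)cc2)nc1Nc1c(F)cc(-c2ccnc(F)c2)cc1F`: 167000 nM
- compound 3 `Cc1cc(-c2ccnc3ccccc23)cc(C)c1Nc1ccnc(Nc2ccc(C#N)cc2)n1`: 3500 nM

Compound 3 has the lowest number of the three, so it is the most toxic in this assay, well beyond the scatter of compound 1 and compound 2. The next compound, compound 4 `Cc1cc(-c2cc(C)c(Nc3ccnc(Nc4ccc(C#N)cc4)n3)c(C)c2)ccn1`, carries 2-methylpyridin-4-yl in place of quinolin-4-yl on an aromatic carbon.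

Among the compounds with values here, no measured step starts from compound 3, so the evidence is thin. Within the data shown here, the only step available is a 1.6-fold lower number from compound 1 to compound 2 (0.19 log units; within the scatter), where 2-fluoropyridin-4-yl replaces thiophen-3-yl on an aromatic carbon. That exchange of one ring for another stayed within the scatter, so a very large move is not expected here. Compound 3 sits at the low end with 3500 nM, so any drift is expected to be upward, towards lower toxicity in this test. The expected change is modest, close to the edge of the scatter, at a 2.3-fold higher number from compound 3 to compound 4 (0.36 log units; beyond the scatter). Compound 4 is estimated at 8000 nM, with an expected range of 2500 nM to 40000 nM.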

Compound 4, half-maximal cytotoxic concentration: 4900 nM
Beside the measured number, compound 4's estimate is 1.6-fold (0.21 log units) above it, within the range that was stated.
By their numbers in this assay, from the lowest: compounds 3 and 4 (each within the scatter of the next); then compounds 2 and 1 (each within the scatter of the next).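

In this assay, exchanging quinolin-4-yl for 2-methylpyridin-4-yl gives a 1.4-fold higher number from compound 3 to compound 4 (0.15 log units; within the scatter), so the two compounds cannot be told apart. Within the data shown here, this exchange removes the six-membered aromatic ring of carbon only and takes the group from 10 heavy atoms to 7, yet the number at this position, para to a large group, stays within the usual scatter, which is the first such reading on the core of compound 3. Nothing available explains why the number holds across this change.

As far as these compounds go, both groups compared here are aromatic and contain a ring nitrogen, so it remains open how a non-aromatic group, such as an amine or a carboxylic acid, would read at this position. From the compounds shown here alone, it is also open whether the same exchange would stay within the scatter on the core of compound 1.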